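Replacing the 3-fluorophenyl Group on a Carbonyl Carbon

The source may report more compounds than this note shows. Statements on the series, on what has been measured and on what is new or still open speak of the compounds shown alone.

Compound 3 `O=C(OC1CCC(CN2CCN(c3cc(=O)c4cc(C(F)(F)F)cc([N+](=O)[O-])c4s3)CC2)CC1)c1cccc(F)c1` sits at the edge of what an ADME assay on Vero cells (Chlorocebus sabaeus) for cytotoxicity, read by MTT assay, with a stated time of 48 h (on this read-out higher numbers stand for weaker inhibition and lower numbers for stronger inhibition), can read. In this assay compound 3 gives > 64 ug/mL, which is a limit and not a number. Two relatives share its core. In this assay compound 1 `O=C(OC1CCC(CN2CCN(c3cc(=O)c4cc(C(F)(F)F)cc([N+](=O)[O-])c4s3)CC2)CC1)c1ccccc1` gives > 64 ug/mL, again a limit. In this assay compound 2 `CCCC(=O)OC1CCC(CN2CCN(c3cc(=O)c4cc(C(F)(F)F)cc([N+](=O)[O-])c4s3)CC2)CC1` gives > 64 ug/mL, also a limit. The whole picture so far is the limit of > 64 ug/mL in this assay, at which 3 of the 3 values shown sit.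

Compound 4 `O=C(OC1CCC(CN2CCN(c3cc(=O)c4cc(C(F)(F)F)cc([N+](=O)[O-])c4s3)CC2)CC1)c1ccc2c(c1)OCC2` differs from compound 3 in one place, on a carbonyl carbon: a group of 9 heavy atoms (8 carbon, 1 oxygen; one five-membered non-aromatic ring with 1 hetero atom, one six-membered aromatic ring of carbon only) in place of a group of 7 heavy atoms (6 carbon, 1 fluorine; one six-membered aromatic ring of carbon only), on a carbonyl carbon.

Among the compounds with values here, three measured steps bear on this change, as each alters the group carried by that carbonyl carbon: a step that the two limits leave unreadable from compound 1 to compound 2, a step that the two limits leave unreadable from compound 1 to compound 3 and a step that the two limits leave unreadable from compound 2 to compound 3. None of them has a readable size, so they offer no measured direction. Compounds 1, 2 and 3 all rest at the same limit despite their different groups, so no step beyond the usual scatter is expected in this assay, and no direction can be named. The estimated change is a number no higher from compound 3 to compound 4 (the limit leaves the size open). In this assay the expected value for compound 4 is 64 ug/mL, with an estimated range from 32 ug/mL to 128 ug/mL, and it will most likely be reported only as a limit.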

Compound 4, half-maximal inhibitory concentration: > 64 ug/mL
Compound 4: a limit, no number; the forecaster's own chance of this, stated with the estimate: 85%; the middle value sits exactly at the limit.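

Compound 4 gives only a limit in this assay, as do compounds 1, 2 and 3, so none of the steps linking compound 4 to those three can be read: the limit of > 64 ug/mL in this assay, at which 4 of the 4 values shown sit.

Whether the group on the carbonyl carbon changes the result in this assay at all stays open, with no compound shown giving a number.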